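The source may hold more compounds than are shown below. What is called first, only, known or untested is meant among the compounds shown, and "the series" means these compounds.

Compound 3 `Oc1cc(C(F)(F)F)ccc1-c1nc(-c2ccccc2O)n(-c2ccc(Br)cc2)n1` gives 100% in a functional assay on PC-12 cells (Rattus norvegicus) for cytotoxicity, read by MTT assay, with stated times of 2 h and 24 h, tested at 10 uM; on this read-out higher numbers stand for a stronger effect at the one concentration tested and lower numbers for a weaker effect. Among the three measured compounds it sits between the others: the nearest is compound 2 `Oc1cc(C(F)(F)F)ccc1-c1nc(-c2ccccc2O)n(-c2ccc(F)cc2)n1` with 99.8%, and the furthest is compound 1 `Cc1ccc(-n2nc(-c3ccc(C(F)(F)F)cc3O)nc2-c2ccccc2O)cc1` with 102%, both within the scatter, so none of the three can be told apart from the others. Compound 4 `Oc1cc(C(F)(F)F)ccc1-c1nc(-c2ccccc2O)n(-c2ccc(C(F)(F)F)cc2)n1` differs from compound 3 by trifluoromethyl in place of bromo on an aromatic carbon. Among the compounds with values here, the steps that bear on this change are those at the same place: a number 0.2 percentage points higher from compound 2 to compound 3 (within the scatter) and a number 2 percentage points lower from compound 1 to compound 3 (within the scatter). Three different groups there have given numbers that cannot be separated, so no step beyond the scatter is expected, no change at the digits printed from compound 3 to compound 4 (within the scatter). Compound 4 is therefore estimated at 100%, with a range from 90% to 110%.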

Compound 4, a percentage reported as activity, at one concentration (the size of the read-out at that concentration, not a potency): 102%
Compound 4: the middle estimate sits 2 percentage points below what was measured, within the range that was stated.
By their numbers in this assay, from the lowest: compounds 2, 3, 1 and 4 (each within the scatter of the next).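

Trifluoromethyl is a fourth group on this aromatic carbon, and in this assay it gives a number 2 percentage points higher from compound 3 to compound 4 (within the scatter) and a number 2.2 percentage points higher from compound 2 to compound 4 (within the scatter) and also no change at the digits printed from compound 1 to compound 4 (within the scatter). Methyl, fluoro, bromo and trifluoromethyl at this place therefore cannot be told apart on this read-out. Nothing available offers a reason for this flat result.

As far as these compounds go, whether an amine, a carboxylic acid or a longer chain at this place would separate from these four remains open. So does the effect of changing any other part of the shared core.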